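The compounds below may be only part of what the source reports. "The series", "measured", "known", "first", "only" and "open" are said of these compounds alone.

Working notes on the series. Compound 1 `CCC(CC)(c1ccc(OCC(O)C(C)(C)C)c(C)c1)c1ccc(C(=O)N[C@@H](C)CO)n1C` gives 570 nM in an assay on HL-60 cells for agonist activity at vitamin D3 receptor (Homo sapiens), with a stated time of 96 h (on this read-out higher numbers stand for an effect only at larger amounts of compound and lower numbers for an effect already at smaller amounts), the highest of the three numbers in hand. Within the data shown here, compound 2 `CCn1c(C(=O)N[C@@H](C)CO)ccc1C(CC)(CC)c1ccc(OCC(O)C(C)(C)C)c(C)c1` gives 1.06 nM, and the only single-point step measured, a 540-fold lower number from compound 1 to compound 2 (2.73 log units; beyond the scatter), concerns the substituent on the aromatic nitrogen and not the amide side chain. Compound 3 `CCC(CC)(c1ccc(OCC(=O)C(C)(C)C)c(C)c1)c1ccc(C(=O)N[C@@H](CC(=O)O)C(=O)O)n1C` differs from compound 1 in two places, one of them on the amide-type nitrogen. In this assay compound 3 gives 410 nM; the two values lie within the scatter of each other, which is the only hint that alterations at that nitrogen may pass without a large shift.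

Compound 4 `CCC(CC)(c1ccc(OCC(O)C(C)(C)C)c(C)c1)c1ccc(C(=O)NCCC(=O)O)n1C` carries the change (2-carboxyethyl in place of 1-(hydroxymethyl)ethyl on an amide-type nitrogen). Among the measured compounds shown here, no measured step bears directly on this change; the compound 1 to compound 3 comparison is the nearest, and it shows no movement beyond the scatter. For compound 4 the step of a 1.1-fold lower number from compound 1 to compound 4 (0.06 log units; within the scatter) is therefore expected to be small, with no direction beyond the scatter. Compound 4 is estimated at 500 nM, within 150 nM to 1700 nM.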

Compound 4, half-maximal effective concentration: 1600 nM
Estimate against measurement, compound 4: 3.2-fold (0.51 log units) below, within the range that was stated.
By their numbers in this assay, from the lowest: compound 2; then compounds 3 and 1 (each within the scatter of the next); then compound 4.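

In this assay the amide-type nitrogen now has its first single-point reading: 2-carboxyethyl in place of 1-(hydroxymethyl)ethyl gives a 2.8-fold higher number from compound 1 to compound 4 (0.45 log units; beyond the scatter) as a modest step. Alterations at this nitrogen therefore do not always pass within the scatter, as the two-place comparison involving compound 3 had hinted, though this step remains much smaller than a 540-fold lower number from compound 1 to compound 2 (2.73 log units; beyond the scatter) for the substituent on the aromatic nitrogen. No available evidence bears on the origin of this shift.

The change replaces the whole group, so the contributions of the carboxyl end, the chain shape and the defined stereocentre cannot be separated. Also open, as far as these compounds go, are what an amine or a longer chain would give on this nitrogen, and whether the 2-carboxyethyl step would hold on the background of compound 2.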